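The source may report more compounds than this note shows. Statements on the series, on what has been measured and on what is new or still open speak of the compounds shown alone.

Measured compounds:
Compound 1, `Cc1cc(Oc2ccc(/C=N/NC(=S)Nc3ccc(Br)cc3)cc2)ccc1Cl`: in a physicochemical assay for lipophilicity, in phosphate buffer, measured as octanol-water partition, with a stated time of 24 h (on this read-out higher numbers stand for higher lipophilicity and lower numbers for lower lipophilicity), compound 1 gives 7.89.
Compound 2, `O=[N+]([O-])c1ccc(Oc2ccc(/C=N/NC(=S)Nc3ccc(Cl)cc3)cc2)cc1`: in this assay compound 2 gives 5.52.

Among the compounds with values here, of these two numbers compound 2 stands lowest; its only neighbour, compound 1, lies higher by a gap beyond the usual scatter. Within the data shown here, no step between the two measured compounds is set out here, as they differ in more than one place, so only their two values speak.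

Compound 3, `Cc1cc(Oc2ccc(/C=N/NC(=S)Nc3ccc(Cl)cc3)cc2)ccc1Cl`, is not yet measured. It differs from compound 2 by 4-chloro-3-methylphenyl in place of 4-nitrophenyl on an oxygen on an aromatic ring. The entering group is the same one that compound 1 carries on that oxygen, and compound 1 gives 7.89, so compound 3 is expected to climb well beyond the scatter, by about a number 2.08 log units higher from compound 2 to compound 3 (beyond the scatter). For compound 3 the estimate in this assay is 7.6, with a range from 6.8 to 8.4.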

Compound 3, partition coefficient: 6.59
For compound 3 the middle estimate is 1.01 log units above the measured one; measured number outside the range, below it.
By their numbers in this assay, from the lowest: compound 2; then compound 3; then compound 1.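

Within the data shown here, replacing 4-nitrophenyl with 4-chloro-3-methylphenyl on the oxygen now has a directly measured effect in this assay, with a number 1.07 log units higher from compound 2 to compound 3 (beyond the scatter) as the only structural change between the pair. Compound 3 also isolates a second site, as chloro in place of bromo on an aromatic carbon gives a number 1.30 log units lower from compound 1 to compound 3 (beyond the scatter), so the number here does not depend on the group on the oxygen alone. No measurement shown explains either step.

As far as these compounds go, it remains open how this read-out would respond if the phenyl on the oxygen carried an amine or a carboxylic acid instead. Also unsettled is whether the chloro-for-bromo step would keep its size with 4-nitrophenyl on the oxygen, and how fluoro or methoxy would compare on that aromatic carbon.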